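The compounds below may be only part of what the source reports. "The series", "measured", "known", "first", "only" and "open" are said of these compounds alone.

Compound 3 `COc1cccc(OS(=O)(=O)/C=C/c2ccccc2Cl)c1` holds the highest of the two numbers read in an assay on U2OS cells for activation of nuclear factor erythroid 2-related factor 2 (Homo sapiens), read by chemiluminescence, with a stated time of 6 h; a lower number here means that less compound is needed, a higher number that more compound is needed for the effect. In this assay compound 3 gives 165 nM. Its nearest neighbour, compound 2 `COc1ccccc1OS(=O)(=O)/C=C/c1ccccc1Cl`, gives 76 nM in this assay, a gap that lies beyond the usual scatter. Compound 1 `O=S(=O)(/C=C/c1ccccc1)Nc1ccccc1` returns only a limit in this assay, > 10000 nM. Compound 4 `COc1cccc(OS(=O)(=O)/C=C/c2ccc(Cl)cc2)c1` has not been measured; it differs from compound 3 by 4-chlorophenyl in place of 2-chlorophenyl on a double-bonded chain carbon bound to a double-bonded chain carbon. Within the data shown here, no measured pair shows this change, so the size of the step in this assay is open; a modest rise in the number is expected, rather than none beyond the scatter. Compound 4 is expected at 350 nM, within a range from 80 nM to 1500 nM. The expected step from compound 3 to compound 4 in this assay is a 2.1-fold higher number from compound 3 to compound 4 (0.33 log units; beyond the scatter).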

Compound 4, half-maximal effective concentration: 1780 nM
Compound 4: the middle estimate sits 5.1-fold (0.71 log units) below what was measured; measured number above the stated range.
By their numbers in this assay, from the lowest: compound 2; then compound 3; then compound 4. At a limit, above all of these: compound 1.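

In this assay, moving the chlorine while keeping the same atoms gives an 11-fold higher number from compound 3 to compound 4 (1.03 log units; beyond the scatter) on a double-bonded chain carbon bound to a double-bonded chain carbon. Among these compounds, this pair is the first to show that 2-chlorophenyl and 4-chlorophenyl are not interchangeable at this place, with 2-chlorophenyl needing less compound. Nothing shown accounts for the size of this step.

Going by these compounds, whether a nitrile in place of the chlorine would behave like either group remains open. So does whether the same change would carry the same cost on the core of compound 2.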